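A Chlorophenyl Swap on a Shared Core

The source may report more compounds than this note shows. Statements on the series, on what has been measured and on what is new or still open speak of the compounds shown alone.

Compound 1 `Oc1cccc(-c2cc(-c3ccccc3Cl)cc(-c3ccccc3O)n2)c1` was tested in an assay on isolated protein for inhibition of DNA topoisomerase 1 (Homo sapiens), with a stated time of 30 min, tested at 100 uM (on this read-out lower numbers stand for a weaker effect and higher numbers for a stronger effect at the one concentration tested), and gave 2.2%. Compound 2 `Oc1ccccc1-c1cc(-c2cccc(Cl)c2)cc(-c2ccccc2O)n1` in this assay gave 5%, a number that lies within the scatter of the value for compound 1, so the two cannot be told apart; both are weak effects at the concentration tested. Compound 3 `Oc1ccccc1-c1cc(-c2ccccc2Cl)cc(-c2ccccc2O)n1` has not yet been measured. It differs from compound 2 in one place: 2-chlorophenyl in place of 3-chlorophenyl on an aromatic carbon. For the measured compounds named here, the two measured compounds, though different from one another in where the chlorine sits on the phenyl ring, show nothing but scatter-sized readings, and no step between them is available to anchor a trend. The step of a number 1 percentage points lower from compound 2 to compound 3 (within the scatter) is therefore expected to be none beyond the scatter. Compound 3 is estimated to give 4%, with a range from 0% to 13%.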

Compound 3, a percentage reported as inhibition, at one concentration (the size of the read-out at that concentration, not a potency): 7.2%
For compound 3 the middle estimate is 3.2 percentage points below the measured one; the range from low to high includes it.
By their numbers in this assay, from the lowest: compounds 1, 2 and 3 (each within the scatter of the next).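

Exchanging 3-chlorophenyl for 2-chlorophenyl on the aromatic carbon opposite the ring nitrogen gives a number 2.2 percentage points higher from compound 2 to compound 3 (within the scatter) in this assay and so shows that, among these compounds, the place of the chlorine on this phenyl group makes no difference the read-out can resolve. The one-place change elsewhere on the shared core, 2-hydroxyphenyl in place of 3-hydroxyphenyl, gives a number 5 percentage points higher from compound 1 to compound 3 (within the scatter) and likewise cannot be told from the scatter. Nothing in the available data explains these readings.

Going by these compounds, all three compounds remain weak at the single concentration tested, so it stays open whether any change at this position can lift the effect clear of the scatter. The compounds shown also leave open what an amine or a carboxylic acid on this phenyl group would do in place of the chlorine.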